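A Thiophene Ring in Place of Furan on the Core

A few compounds are considered here, and "the series" means these few. Any claim that something is new, unique, unknown or untested is made for them only; others in the source may bear on it.

Of the compounds shown here, three built on one shared core have been measured in an assay on membranes from HeLa cells for displacement of a labelled ligand from adenosine receptor A3 (Homo sapiens), read by scintillation counting, with a stated time of 180 min, tested at 1 uM; on this read-out higher numbers stand for more inhibition at the one concentration tested (going by the name of the read-out) and lower numbers for less inhibition. Compound 1 `CCCOC(=O)C1=C(C)N(C)C(=O)NC1c1ccco1` gives 8%, the lowest of the three numbers. Compound 2 `CC1=C(C(=O)OCC(C)C)C(c2ccco2)NC(=O)N1C` gives 23%, and compound 3 `CC1=C(C(=O)OC(C)(C)C)C(c2ccco2)NC(=O)N1C` gives 54%. Every measured step concerns the group on the oxygen next to the carbonyl: a number 15 percentage points higher from compound 1 to compound 2 (beyond the scatter), a number 46 percentage points higher from compound 1 to compound 3 (beyond the scatter) and a number 31 percentage points higher from compound 2 to compound 3 (beyond the scatter).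

Compound 4 `CCCOC(=O)C1=C(C)N(C)C(=O)NC1c1cccs1` differs from compound 1 in another place: thiophen-2-yl in place of furan-2-yl on a saturated ring carbon. Among the measured compounds shown here, none of the measured steps bears on this exchange; each of them alters the ester group while the furan-2-yl ring stays untouched, and no measured pair shares the ester while differing in that ring. The step from compound 1 to compound 4 thus has no precedent among these compounds. The two rings exchanged are each five-membered and aromatic with one hetero atom, so no change beyond the usual scatter is expected in this assay, and the step is estimated as a number 2 percentage points higher from compound 1 to compound 4 (within the scatter). Compound 4 is accordingly expected to give about 10% in this assay, within a range from 0% to 25%.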

Compound 4, a percentage reported as inhibition, at one concentration (the size of the read-out at that concentration, not a potency): 4%
Compound 4: middle estimate off by 6 percentage points, on the high side; the range from low to high includes it.
By their numbers in this assay, from the lowest: compounds 4 and 1 (each within the scatter of the next); then compound 2; then compound 3.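

Among the compounds shown here, until now only the ester group had been varied, so this is the first reading at the ring on the saturated ring carbon of the shared core: in this assay there is a number 4 percentage points lower from compound 1 to compound 4 (within the scatter) when thiophen-2-yl takes the place of furan-2-yl. With the propoxycarbonyl group in place, the read-out therefore does not separate these two rings, although the exchange of the ester group on the furan-2-yl compounds gave a number 46 percentage points higher from compound 1 to compound 3 (beyond the scatter) and so moved the number beyond the scatter. Nothing available explains why this ring exchange leaves the number within the scatter.

As far as these compounds go, the exchange has been read only at low inhibition, with compound 1 at 8% and compound 4 at 4%, so it remains open whether thiophen-2-yl would also match furan-2-yl on the tert-butyl ester, where compound 3 gives 54% with furan-2-yl in place. The compounds shown also leave open what a phenyl ring or a pyridine ring would give on the same saturated ring carbon.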